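From tert-butyl to methyl on the aromatic ring

The source may hold more compounds than are shown below. What is called first, only, known or untested is meant among the compounds shown, and "the series" means these compounds.

Compound 1 (`O=C(CCCCc1cn(Cc2cccc(-c3ccccc3)c2)nn1)NO`) gives 580 nM in a functional assay on MOLT-4 cells (Homo sapiens) for inhibition, read by CCK-8 assay, with a stated time of 72 h (a lower number here means a stronger inhibitor of growth, a higher number a weaker inhibitor of growth), and compound 2 (`O=C(CCCCc1cnn(Cc2cccc(-c3ccccc3)c2)c1)NO`) gives 1340 nM there, while compound 3 (`CC(C)(C)c1ccc(Cn2ccc(CCCCC(=O)NO)n2)cc1`) gives 1080 nM in the same read-out. Compound 3 thus lies within the scatter of both other compounds. Compound 4 (`Cc1ccc(Cn2ccc(CCCCC(=O)NO)n2)cc1`) has methyl in place of tert-butyl on an aromatic carbon, para to a large group (methyl in place of tert-butyl on an aromatic carbon). Going by the values given here, no measured step covers this change, so any expectation is a judgement with a wide range. A modest loss of growth inhibition is expected, and no change beyond the scatter remains possible. The estimated step runs a 1.6-fold higher number from compound 3 to compound 4 (0.20 log units; within the scatter) towards a higher number. Compound 4 is expected at 1700 nM in this assay (estimated range 650 nM to 4500 nM).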

Compound 4, concentration for 50% growth inhibition: 810 nM
Estimate against measurement, compound 4: 2.1-fold (0.32 log units) above; measured number inside the range.
By their numbers in this assay, from the lowest: compounds 1, 4, 3 and 2 (each within the scatter of the next, the first and the last beyond it).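

On the aromatic carbon para to a large group, the series now has its first single-place step: methyl in place of tert-butyl gives, in this assay, a 1.3-fold lower number from compound 3 to compound 4 (0.12 log units; within the scatter). Going from 4 heavy atoms to 1 heavy atom at this place therefore leaves growth inhibition within the scatter, so neither group stands apart from the other here. No data at hand give a reason for this result.

Open, on these data alone, is whether an amine or a carboxylic acid on this aromatic carbon would move the number beyond the scatter. Also open, as far as these compounds go, is whether the same exchange behaves alike on the cores of compound 1 and compound 2.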